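From cyclopropylmethyl to oxolan-3-yl on the shared core

The source may hold more compounds than are shown below. What is called first, only, known or untested is meant among the compounds shown, and "the series" means these compounds.

Compound 1 `CC(C)(O)CNc1c(-c2ccccn2)nc2ccccn12`: > 50000 nM (a limit)
Compound 2 `c1ccc(-c2nc3ccccn3c2NCC2CC2)nc1`: 19400 nM

Within the data shown here, in an ADME assay on THP-1 cells (Homo sapiens) for cytotoxicity (a higher number here means that more compound is tolerated, a lower number that less compound is tolerated), compound 2 holds the only exact number, 19400 nM. The result for compound 1 is a limit, as the limit of > 50000 nM in this assay, at which 1 of the 2 values shown sits, records. Compound 3 `c1ccc(-c2nc3ccccn3c2NC2CCOC2)nc1` is still unmeasured, and it differs from compound 2 as follows: oxolan-3-yl in place of cyclopropylmethyl on a nitrogen on an aromatic ring. Among the measured compounds shown here, only one measured step bears on this change, an at least 2.5-fold lower number from compound 1 to compound 2 (0.41 log units; beyond the scatter), and it also ends on the cyclopropyl compound with the lower number. That single step is thin support, so only a modest move is expected in this assay, an estimated 1.6-fold higher number from compound 2 to compound 3 (0.22 log units; within the scatter). For compound 3 the expected value is 32000 nM, with an estimated range of 15000 nM to 65000 nM.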

Compound 3, half-maximal cytotoxic concentration: > 50000 nM
Compound 3: a limit, no number (the forecaster's own chance of this, stated with the estimate: 35%); middle value at least 1.5-fold (0.19 log units) from the limit.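

In this assay, oxolan-3-yl in place of cyclopropylmethyl on the nitrogen gives an at least 2.5-fold higher number from compound 2 to compound 3 (0.41 log units; beyond the scatter), so this position responds to a change of ring as well as to the change of side chain seen earlier. Among the three compounds, the two that reach the limit each carry an oxygen, while compound 2 carries none. The readings of compound 1 and compound 3 are limits, not numbers, and the step between them cannot be read: the limit of > 50000 nM in this assay, at which 2 of the 3 values shown sit.

Left open is whether an oxygen is needed at all, and whether a piperidin-4-yl or a longer chain on the same nitrogen would also reach that limit.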